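This account rests on a few compounds, and the source may have more. Where it says the series, first, only, none or still open, it means among the compounds named here.

Among the three measured compounds, compound 2 `N#Cc1ccc(Nc2cnccc2SCc2ccccc2C(=O)O)c2ccccc12` stands lowest in an assay on HEK293 cells for inhibition of solute carrier family 22 member 12 (Homo sapiens), read by scintillation counting, with stated times of 30 min and 15 min (on this read-out lower numbers stand for stronger inhibition and higher numbers for weaker inhibition), with 240 nM. Compound 1 `CC(C)(Sc1ccncc1Oc1ccc(C#N)c2ccccc12)C(=O)O` gives 5210 nM and compound 3 `N#Cc1ccc(Oc2cnccc2SCC(=O)O)c2ccccc12` gives 6970 nM; the step of a 1.3-fold higher number from compound 1 to compound 3 (0.13 log units; within the scatter) changes only the acid arm on the sulfur. Compound 4 `N#Cc1ccc(Nc2cnccc2SCCCCCC(=O)O)c2ccccc12` differs from compound 2 in that (4-carboxybutyl in place of 2-carboxyphenyl on a saturated chain carbon bound to a sulfur). Among the compounds with values here, no measured step removes an aromatic ring from this arm; the one measured step, carboxymethyl for 1-carboxy-1-methylethyl, stays within the scatter, while compound 2 sits far below compound 1 and compound 3, both carrying shorter acid arms without a ring. The author therefore expects a moderately higher number for compound 4, a 5.0-fold higher number from compound 2 to compound 4 (0.70 log units; beyond the scatter), estimating 1200 nM with a range from 300 nM to 5000 nM.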

Compound 4, half-maximal inhibitory concentration: 4240 nM
The estimate for compound 4 lay 3.5-fold (0.55 log units) below the measured number, and the stated range covers the measured number.
By their numbers in this assay, from the lowest: compound 2; then compounds 4, 1 and 3 (each within the scatter of the next).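

Within the data shown here, exchanging 2-carboxyphenyl for 4-carboxybutyl on a saturated chain carbon bound to a sulfur gives an 18-fold higher number from compound 2 to compound 4 (1.25 log units; beyond the scatter) in this assay and is the first measured step at this position to take out the aromatic ring. It shows that keeping a carboxylic acid on an open chain does not keep the number of compound 2. Ring and chain still change together in this one step, so neither can be credited alone.

Open, on these data alone, is what a longer chain, or an amide or tetrazole in place of the carboxylic acid, would give. No evidence here explains the size of this step.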